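The compounds below may be only part of what the source reports. "The series", "measured", "known", "first", "only" and "open" are said of these compounds alone.

Compound 1 `CCC(CC)(c1ccc(OCC(=O)C(C)(C)CCCc2ccccc2)c(C)c1)c1ccc(OC[C@@H](O)CO)c(C)c1`: in an assay on HL-60 cells for activation of vitamin D3 receptor (Homo sapiens) (a higher number here means that more compound is needed for the effect, a lower number that less compound is needed), compound 1 gives > 30000 nM, which is a limit of the assay, not a number.
Compound 2 `CCC(CC)(c1ccc(OCC(O)C(C)(C)CCc2ccccc2)c(C)c1)c1ccc(OC[C@@H](O)CO)c(C)c1`: in this assay compound 2 gives 7100 nM.

Among the measured compounds shown here, compound 2 therefore holds the only numerical value here; the other result is a limit (the limit of > 30000 nM in this assay, at which 1 of the 2 values shown sits). Compound 3 `CCC(CC)(c1ccc(OCC(O)C(C)(C)Cc2ccc3ccccc3c2)c(C)c1)c1ccc(OC[C@@H](O)CO)c(C)c1` is not yet measured. It differs from compound 2 by naphthalen-2-yl in place of benzyl on a saturated chain carbon, three bonds along the chain from an oxygen on a saturated carbon; cut one bond further out, the same difference reads phenethyl to (naphthalen-2-yl)methyl. For the measured compounds named here, no measured pair shows a change of this kind, so nothing here sets the size of the step. Compound 3 is expected to stay close to compound 2, with an expected step of a 1.4-fold lower number from compound 2 to compound 3 (0.15 log units; within the scatter) not beyond the usual scatter. The estimate for compound 3 is 5000 nM, with a range from 1500 nM to 20000 nM.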

Compound 3, half-maximal effective concentration: > 30000 nM
Compound 3: only a limit was reported; the forecaster's own chance of this, stated with the estimate: 20%; middle value at least 6.0-fold (0.77 log units) from the limit.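

In this assay, naphthalen-2-yl in place of benzyl gives an at least 4.2-fold higher number from compound 2 to compound 3 (0.62 log units; beyond the scatter), so this end of the molecule is sensitive to a change in its aromatic group. The result for compound 3 is a limit of the assay, so the full size of the step remains unknown: the limit of > 30000 nM in this assay, at which 2 of the 3 values shown sit.

The compounds shown cannot separate the effect of the added ring from that of the changed link, as phenethyl to (naphthalen-2-yl)methyl also reads. As far as these compounds go, it remains open whether naphthalen-2-yl on a longer chain, or an amine on the benzyl group, would give a measurable value.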